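Ring change at the amine of compound 1

The source may report more compounds than this note shows. Statements on the series, on what has been measured and on what is new or still open speak of the compounds shown alone.

Compound 1 `N#Cc1cnc(NCc2cnccc2C(F)(F)F)cc1NC[C@H]1C[C@H](O)C1` sits at the edge of an assay on isolated protein for inhibition of protein kinase C delta type (Homo sapiens), read by TR-FRET, with a stated time of 2 h; on this read-out lower numbers stand for stronger inhibition and higher numbers for weaker inhibition. In this assay compound 1 gives > 10000 nM, which is a limit of the assay and not a number (the limit of > 10000 nM in this assay, at which 1 of the 3 values shown sits). Within the data shown here, compound 2 `CC(C)(F)c1ncncc1CNc1cc(N[C@H]2CC[C@@H](O)CC2)c(C#N)cn1` gives 32 nM in this assay and compound 3 `N#Cc1cnc(NCc2cncnc2-c2ccccc2)cc1N[C@H]1CC[C@@H](O)CC1` gives 90 nM; the one measured step, a 2.8-fold higher number from compound 2 to compound 3 (0.45 log units; beyond the scatter), changes a different part of the molecule from the one changed here.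

Compound 4 `CC1(C)C[C@H](Nc2cc(NCc3cnccc3C(F)(F)F)ncc2C#N)CC[C@H]1O` differs from compound 1 in one place: 4-hydroxy-3,3-dimethylcyclohexyl in place of (3-hydroxycyclobutyl)methyl on a nitrogen on an aromatic ring. Among the measured compounds shown here, no measured pair alters this position, so the step has no direct precedent. At this nitrogen, compound 2 and compound 3 resemble compound 4 rather than compound 1, and both return numbers well inside the range of this assay, whereas compound 1 with its smaller ring gives only a limit. An improvement beyond the scatter is therefore expected for compound 4, as the step of an at least 33-fold lower number from compound 1 to compound 4 (1.52 log units; beyond the scatter). Compound 4 is estimated at 300 nM, within 60 nM to 3000 nM.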

Compound 4, half-maximal inhibitory concentration: 2200 nM
For compound 4 the middle estimate is 7.3-fold (0.87 log units) below the measured one, within the range that was stated.
By their numbers in this assay, from the lowest: compound 2; then compound 3; then compound 4. At a limit, above all of these: compound 1.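

In this assay, among these compounds, 4-hydroxy-3,3-dimethylcyclohexyl in place of (3-hydroxycyclobutyl)methyl on this nitrogen gives an at least 4.5-fold lower number from compound 1 to compound 4 (0.65 log units; beyond the scatter), the first measured step at this position, and it shows that the group here can move the read-out beyond the scatter. Compound 1 sits at a limit of the assay and not at a number: the limit of > 10000 nM in this assay, at which 1 of the 4 values shown sits. Going by these compounds, the printed size of the step is therefore a lower bound, and the full size remains unknown.

The change alters the ring size, the methylene link and the two ring methyl groups together, so the compounds shown do not separate the share of each. Also open, on these data alone, is what the hydroxyl contributes at this position, which a 4-aminocyclohexyl or an unsubstituted cyclohexyl on the same nitrogen of the core of compound 4 would address.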